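Swapping Bromo for Trifluoromethyl on the Aryl Ring

The source may hold more compounds than are shown below. What is called first, only, known or untested is meant among the compounds shown, and "the series" means these compounds.

Of the compounds shown here, three built on one shared core have been tested in a functional assay on the whole organism with Mus musculus as the target; a higher number here means that more compound is needed for the effect, a lower number that less compound is needed. Compound 1 `Nc1nc2ccnc(Cc3cccc(C(F)(F)F)c3)n2n1` gives 178 mg/kg. Compound 2 `Nc1nc2ccnc(-c3cccc(Br)c3)n2n1` gives 142 mg/kg, and compound 3 `Nc1nc2ccnc(-c3ccccc3F)n2n1` gives 218 mg/kg. Compound 2 cannot be set apart from the others: compounds 1 and 3 both lie within the usual scatter of it. Compound 4 `Nc1nc2ccnc(-c3cccc(C(F)(F)F)c3)n2n1` has not yet been measured. It differs from compound 2 in one place: trifluoromethyl in place of bromo on an aromatic carbon. For the measured compounds named here, no measured pair shows what such a change does here, so in this assay a step no larger than the scatter is expected, in either direction. Compound 4 is therefore estimated to give about 160 mg/kg, likely between 80 mg/kg and 320 mg/kg. This expectation corresponds to a 1.1-fold higher number from compound 2 to compound 4 (0.05 log units; within the scatter).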

Compound 4, dose for half-maximal effect: 166 mg/kg
Compound 4: middle estimate off by 1.0-fold (0.02 log units), on the low side; low and high end bracket the measured number.
By their numbers in this assay, from the lowest: compounds 2, 4, 1 and 3 (each within the scatter of the next).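

For the compounds shown here, the swap gives a 1.2-fold higher number from compound 2 to compound 4 (0.07 log units; within the scatter) in this assay at this place on the aryl ring, and it is the first step in the set between compounds that differ in one place only. Trifluoromethyl brings more heavy atoms than bromo, yet the two compounds cannot be told apart. At this position, then, the two groups are interchangeable in this assay, as far as this single pair can show.

Going by these compounds, whether an amine or a carboxylic acid in the same place would move the number beyond the scatter stays open. No measurement shown here bears on the reason for this result.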